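This account rests on a few compounds, and the source may have more. Where it says the series, first, only, none or still open, it means among the compounds named here.

Of the compounds shown here, two with closely related structures have been measured in a functional assay on Huh-7 cells (Homo sapiens) for cytotoxicity, read by MTT assay, with a stated time of 72 h; a higher number here means that more compound is tolerated, a lower number that less compound is tolerated. Compound 1 `CCCS(=O)(=O)N1CCC2(CC1)OOC1(CCCC1)OO2` gives > 100 ug/mL, which is a limit and not a number. Compound 2 `CCCS(=O)(=O)N1CCC2(CC1)OOC1(CCCCCC1)OO2` gives > 100 ug/mL, which is also a limit and not a number. Compound 2 therefore stands with compound 1 at the limit of > 100 ug/mL in this assay, at which 2 of the 2 values shown sit, and no exact value is available for either. Compound 3 `O=S(=O)(Cc1ccccc1)N1CCC2(CC1)OOC1(CCCCCC1)OO2` keeps the core of compound 2 and changes one group: phenyl in place of ethyl on a saturated chain carbon bound to a sulfonyl sulfur. In words, this places phenyl in place of ethyl on a saturated chain carbon bound to a sulfonyl sulfur, or propyl to benzyl when cut one bond further out. Among the measured compounds shown here, no measured step shows what such a change does, so only a small drop, if any beyond the scatter, is expected, with the estimated change being an at least 1.1-fold lower number from compound 2 to compound 3 (0.04 log units; that floor lies within the scatter). Compound 3 is expected to give about 90 ug/mL, within an estimated range of 40 ug/mL to 200 ug/mL.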

Compound 3, half-maximal cytotoxic concentration: > 100 ug/mL
Compound 3: no number, only a limit; the forecaster's own chance of this, stated with the estimate: 60%; middle value at least 1.1-fold (0.04 log units) from the limit.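

Compound 3 gives > 100 ug/mL, which is a limit and not a number, and since compound 2 also stands at a limit, no step can be read between compound 2 and compound 3. The compounds shown leave open whether propyl to benzyl changes the tolerated concentration at all: the limit of > 100 ug/mL in this assay, at which 3 of the 3 values shown sit.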